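Adding a methoxy group to a chalcone with a free hydroxy group

A few compounds are considered here, and "the series" means these few. Any claim that something is new, unique, unknown or untested is made for them only; others in the source may bear on it.

Compound 1 `COc1ccc(O)c(C(=O)/C=C/c2cc(OC)c(OC)c(OC)c2)c1`, compound 2 `COc1cccc(/C=C/C(=O)c2ccccc2O)c1` and compound 3 `COc1ccc(O)c(C(=O)/C=C/c2ccc(OC)c(OC)c2)c1` have been measured in a physicochemical assay for lipophilicity; on this read-out lower numbers stand for lower lipophilicity and higher numbers for higher lipophilicity. Compound 1 gives 3.47, compound 2 gives 3.94 and compound 3 gives 3.52, so compound 2 stands highest of the three. Compound 3 and compound 1 differ in one place, by methoxy in place of hydrogen on an aromatic carbon, and this gave a number 0.05 log units lower from compound 3 to compound 1 (within the scatter). How the core of compound 2 differs from that of compound 3 is not broken down here. Compound 4 `COc1cccc(/C=C/C(=O)c2ccc(OC)cc2O)c1` has not been measured. It differs from compound 2 by methoxy in place of hydrogen on an aromatic carbon. This is the same kind of change as from compound 3 to compound 1, though its surroundings differ: there the entering group sat ortho to a methoxy group, meta to a large group and meta to a methoxy group, here it sits meta to a hydroxy group and para to a large group. Because the earlier change gave a number 0.05 log units lower from compound 3 to compound 1 (within the scatter), a step of about a number 0.04 log units lower from compound 2 to compound 4 (within the scatter) is expected in this assay. Compound 4 is therefore estimated at 3.9, between 3.5 and 4.3.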

Compound 4, partition coefficient: 3.86
Compound 4: the middle estimate sits 0.04 log units above what was measured, and the stated range covers the measured number.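

In this assay, methoxy in place of hydrogen on an aromatic carbon gave a number 0.08 log units lower from compound 2 to compound 4 (within the scatter) and, on the other core, a number 0.05 log units lower from compound 3 to compound 1 (within the scatter) in surroundings that differ, so on both cores shown this change stays inside the usual spread of repeated measurements. This supports carrying the change across these two cores, but only as far as the two pairs go, and steps this small cannot show that the change does nothing in general or that the two cores respond in exactly the same way. Nothing measured here bears on why the steps are this small.

The compounds shown leave open what an amine, a carboxylic acid or a longer chain such as butoxy would do in place of that same hydrogen. They also leave open whether the methoxy step would stay this small at other places on the ring or on cores beyond these two.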